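Lengthening the chain on the ring amine nitrogen

This account rests on a few compounds, and the source may have more. Where it says the series, first, only, none or still open, it means among the compounds named here.

Measured in a functional assay on cells (T-cell line, Homo sapiens) for inhibition; on this read-out lower numbers stand for stronger inhibition and higher numbers for weaker inhibition:
Compound 1 `COc1cccc(CCCN2CCC(COC(c3ccccc3)c3ccccc3)CC2)c1`: 1500 nM
Compound 2 `CCN1CCC(COC(c2ccccc2)c2ccccc2)CC1`: > 20000 nM (a limit of the assay)
Compound 3 `CCCCCCCCN1CCC(COC(c2ccccc2)c2ccccc2)CC1`: 700 nM

Among the compounds with values here, compound 3 holds the lowest number so far, and the comparison with its nearest neighbour is a 2.1-fold lower number from compound 1 to compound 3 (0.33 log units; beyond the scatter), a modest step beyond the scatter. The value for compound 2 is a limit and not a number.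

The next compound is compound 4 `CCCCCCCCCCN1CCC(COC(c2ccccc2)c2ccccc2)CC1`, and the change is ethyl in place of hydrogen on a saturated chain carbon, eight bonds along the chain from an amine nitrogen in a ring. Within the data shown here, the closest precedent is an at least 28-fold lower number from compound 2 to compound 3 (1.45 log units; beyond the scatter), a large step in which hexyl replaces hydrogen at a comparable chain position. Among the measured compounds shown here, only this one purely alkyl comparison is available, and its size is open-ended, so it shows direction more than scale. Compound 3 already sits far down that slope, and ethyl is a smaller addition than hexyl, so a modest further fall in this assay is expected rather than a large one. The estimated step is a 1.8-fold lower number from compound 3 to compound 4 (0.24 log units; within the scatter). Compound 4 is expected to give about 400 nM, within an estimated range from 130 nM to 1300 nM.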

Compound 4, half-maximal inhibitory concentration: 2600 nM
For compound 4 the middle estimate is 6.5-fold (0.81 log units) below the measured one; the whole stated range lies below it.
By their numbers in this assay, from the lowest: compound 3; then compounds 1 and 4 (each within the scatter of the next). At a limit, above all of these: compound 2.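

In this assay, the added ethyl at this place, eight bonds along the chain from the ring amine nitrogen, reverses the direction seen so far, with a 3.7-fold higher number from compound 3 to compound 4 (0.57 log units; beyond the scatter), while heptyl in place of 3-methoxyphenyl leaves a difference within the scatter, with a 1.7-fold higher number from compound 1 to compound 4 (0.24 log units; within the scatter). Among the purely alkyl chains, the long chain still keeps its advantage over the short one, with an at least 7.6-fold lower number from compound 2 to compound 4 (0.88 log units; beyond the scatter), so the number falls and then rises again across these three compounds. The size of that last step is open-ended, since the value of compound 2 is a limit: the limit of > 20000 nM in this assay, at which 1 of the 4 values shown sits.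

Where the lowest number lies along this series remains open, as a hexyl chain and a dodecyl chain do not appear among the compounds shown. Whether a hydroxyl group at the chain end would change the picture also stays unanswered.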